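The source may hold more compounds than are shown below. What is called first, only, known or untested is meant among the compounds shown, and "the series" means these compounds.

The account follows the change from compound 1 `CCOC(=O)C1=C(S[C@@H]2CN[C@H](C(=O)Nc3cccc(C(=O)OCC)c3)C2)[C@H](C)[C@@H]2[C@@H]([C@@H](C)OC(=O)CC)C(=O)N12` to compound 4 `CCOC(=O)C1=C(S[C@@H]2CN[C@H](C(=O)Nc3cccc(C(=O)OCC)c3)C2)[C@H](C)[C@@H]2[C@@H]([C@@H](C)OC(=O)[C@@H](N)C(C)C)C(=O)N12`. In a physicochemical assay for metabolic stability, read by LC-MS, in phosphate buffer, with a stated time of 3 h, at pH 7.4, tested at 50 uM (a higher number here means that more of the compound is left, a lower number that less of the compound is left), compound 1 gives > 95%, which is a limit of the assay rather than a measured number. Compound 2 `C[C@@H](O)[C@H]1C(=O)N2C(C(=O)OCOC(=O)C(C)(C)C)=C(S[C@@H]3CN[C@H](C(=O)Nc4cccc(C(=O)O)c4)C3)[C@H](C)[C@H]12` gives > 95% in this assay, also a limit. Compound 3 `C[C@@H](O)[C@H]1C(=O)N2C3=C(S[C@@H]4CN[C@@H](C4)C(=O)Nc4cccc(c4)C(=O)OCc4oc(=O)oc4COC3=O)[C@H](C)[C@H]12` likewise reaches > 95% in this assay, again a limit. Compound 1 thus stands exactly where everything measured so far stands: the limit of > 95% in this assay, at which 3 of the 3 values shown sit. Going by the values given here, no step between two measured compounds is available, so nothing here shows how far a single change can move the reading in this assay.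

Compound 4 differs from compound 1 in one place: 1-amino-2-methylpropyl in place of ethyl on a carbonyl carbon. The expected step of a number at least 3 percentage points lower from compound 1 to compound 4 (that floor lies within the scatter) is small, pointing downward if anywhere, and is not expected to exceed the usual scatter. Compound 4 is estimated to give 92%, between 80% and 98%, and the assay is expected more often than not to report only its limit again.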

Compound 4, percent of the compound remaining: > 95%
Compound 4: a limit, no number (the forecaster's own chance of this, stated with the estimate: 60%); middle value at least 3 percentage points from the limit.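

In this assay, going by these compounds alone, compound 4 gives > 95%, a limit, and compound 1 also sits at a limit, so no step between the two can be read. The compounds shown leave open how far any single change can move the reading: the limit of > 95% in this assay, at which 4 of the 4 values shown sit.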